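The source may hold more compounds than are shown below. What is called first, only, known or untested is meant among the compounds shown, and "the series" means these compounds.

Measured compounds in an ADME assay on MT4 cells (Homo sapiens) for cytotoxicity, read by MTT assay, with a stated time of 4 days; a lower number here means that less compound is tolerated, a higher number that more compound is tolerated:
- compound 1 `CCOC(=O)c1cnc(N2CCN(Cc3ccc(C#N)cc3)CC2)nc1Oc1c(C)cc(-c2ccc(C#N)cc2)cc1C`: > 125000 nM
- compound 2 `CCOC(=O)c1cnc(N2CCN(Cc3ccccc3C#N)CC2)nc1Oc1c(C)cc(-c2ccc(C#N)cc2)cc1C`: > 125000 nM
- compound 3 `CCOC(=O)c1cnc(N2CCN(Cc3ccc(Br)cc3)CC2)nc1Oc1c(C)cc(-c2ccc(C#N)cc2)cc1C`: > 125000 nM

Each of these values is a limit of the assay, not a number. Compound 1 stands at that limit in this assay, so its position among the three is not fixed by a number. Compound 2 is likewise only a limit. Compound 3 is also only a limit. The three steps between them, a step that the two limits leave unreadable from compound 1 to compound 2, a step that the two limits leave unreadable from compound 1 to compound 3 and a step that the two limits leave unreadable from compound 2 to compound 3, are therefore unreadable in size; all that the series shows is the limit of > 125000 nM in this assay, at which 3 of the 3 values shown sit.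

Compound 4 `CCOC(=O)c1cnc(N2CCN(Cc3cc(F)cc(F)c3)CC2)nc1Oc1c(C)cc(-c2ccc(C#N)cc2)cc1C` differs from compound 1 by 3,5-difluorophenyl in place of 4-cyanophenyl on a saturated chain carbon bound to an amine nitrogen in a ring. For the measured compounds named here, the steps that bear on this change are the two from compound 1, to compound 2 and to compound 3, each at the same place and each unreadable. Going by the values given here, no step in this set has yet moved a value off the limit.

Compound 4 is therefore expected to give 125000 nM in this assay, most likely again as a limit, with a range of 60000 nM to 250000 nM. The step of a number no higher from compound 1 to compound 4 (the limit leaves the size open) is expected to be none beyond the scatter.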

Compound 4, half-maximal cytotoxic concentration: > 125000 nM
Compound 4: no number, only a limit; the forecaster's own chance of this, stated with the estimate: 85%; the middle value lies on the limit itself.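

In this assay compound 4 gives > 125000 nM, a limit and not a number. The steps to compound 4 from compound 1, compound 2 and compound 3 cannot be read. The compounds shown leave open whether any change at this place moves a value off the limit: the limit of > 125000 nM in this assay, at which 4 of the 4 values shown sit.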